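The source may hold more compounds than are shown below. What is called first, only, known or untested is meant among the compounds shown, and "the series" means these compounds.

Measured compounds:
- compound 1 `COc1ccc(C(=O)/C=C/c2ccc(Br)cc2)c2c1C=CC(C)(C)O2`: > 10000 nM
- compound 2 `COc1ccc(C(=O)/C=C/c2ccc(-n3ccnc3)cc2)c2c1C=CC(C)(C)O2`: 7200 nM
- compound 3 `COc1ccc(C(=O)/C=C/c2ccc3ccccc3n2)c2c1C=CC(C)(C)O2`: 2350 nM

In a functional assay on SK-OV-3 cells (Homo sapiens) for antiproliferative activity, read by MTT assay, with a stated time of 24 h (on this read-out lower numbers stand for stronger inhibition and higher numbers for weaker inhibition), compound 1 gives only a limit, > 10000 nM, and no number. Compound 2 gives 7200 nM in this assay, a change of an at least 1.3-fold lower number from compound 1 to compound 2 (0.14 log units; that floor lies within the scatter). Among the measured compounds shown here, compound 3 gives 2350 nM in this assay; no single-site step connects it to compound 1.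

Compound 4 `COc1ccc(C(=O)/C=C/c2ccc(Cl)c(Cl)c2)c2c1C=CC(C)(C)O2` differs from compound 1 by 3,4-dichlorophenyl in place of 4-bromophenyl on a double-bonded chain carbon bound to a double-bonded chain carbon. For the measured compounds named here, none of the measured steps involves this change, so no measured step tells how large it should be. Going by the values given here, the only anchor is compound 1, whose limit of > 10000 nM in this assay, at which 1 of the 3 values shown sits, leaves the starting point open.

Compound 4 is therefore expected near the same region, with a wide range: 9000 nM (2500 nM to 30000 nM), which is an expected step of an at least 1.1-fold lower number from compound 1 to compound 4 (0.04 log units; that floor lies within the scatter).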

Compound 4, half-maximal inhibitory concentration: 9940 nM
The estimate for compound 4 lay 1.1-fold (0.04 log units) below the measured number; low and high end bracket the measured number.
By their numbers in this assay, from the lowest: compound 3; then compounds 2 and 4 (each within the scatter of the next). At a limit, above all of these: compound 1.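

The 3,4-dichlorophenyl group gives a readable number at this place: in this assay, compound 4 gives 9940 nM. Compound 1, with 4-bromophenyl, gives only a limit, > 10000 nM. The step therefore reads as a number no higher from compound 1 to compound 4 (the limit leaves the size open), so this change adds a measured value but no measured effect: the limit of > 10000 nM in this assay, at which 1 of the 4 values shown sits.

What the compounds shown leave open is how a phenyl ring carrying an amine or a carboxylic acid would read at this place. As far as these compounds go, a single chlorine on the phenyl ring also remains open.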